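Adding a Third Fluorine: From Compound 2 to Compound 3

The source may hold more compounds than are shown below. What is called first, only, known or untested is meant among the compounds shown, and "the series" means these compounds.

Of the compounds shown here, two have so far been measured in an assay on cells for inhibition of cytochrome P450 11B2, mitochondrial (Homo sapiens), read by HPLC, with a stated time of 90 min; on this read-out higher numbers stand for weaker inhibition and lower numbers for stronger inhibition. Compound 1 `Fc1ccc2nc(-c3cccnn3)n(C3CC3)c2c1` gives 412 nM in this assay. Compound 2 `N#Cc1ccc2nc(-c3cncnc3C(F)F)n(C3CC3)c2c1` gives 9 nM, the lower of the two numbers and so the stronger inhibitor; its gap to compound 1 lies well beyond the usual scatter of repeated measurements. Compound 3 `N#Cc1ccc2nc(-c3cncnc3C(F)(F)F)n(C3CC3)c2c1` has not yet been measured. It differs from compound 2 in a single place: fluoro in place of hydrogen on a saturated chain carbon bound to an aromatic carbon and two fluorine atoms, so that a difluoromethyl group becomes a trifluoromethyl group. For the measured compounds named here, no measured pair in this set shows what such a change does, and the expectation therefore rests on the small size of the change alone. The expected step is a 1.3-fold higher number from compound 2 to compound 3 (0.12 log units; within the scatter), a shift that would stay within the scatter. Compound 3 is accordingly expected to give about 12 nM in this assay, with a likely range from 4 nM to 35 nM.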

Compound 3, half-maximal inhibitory concentration: 16 nM
Estimate against measurement, compound 3: 1.3-fold (0.12 log units) below; low and high end bracket the measured number.
By their numbers in this assay, from the lowest: compounds 2 and 3 (each within the scatter of the next); then compound 1.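

For the compounds shown here, replacing the difluoromethyl group with a trifluoromethyl group is the first change in this set made in one place only, and in this assay it gives a 1.8-fold higher number from compound 2 to compound 3 (0.25 log units; within the scatter). On this read-out, compound 2 and compound 3 cannot be told apart, so this position accepts one more fluorine on the saturated chain carbon without a change beyond the usual scatter. No available measurement explains this result.

What remains open is how far this tolerance extends, as the compounds shown carry only these two fluorinated groups at this position. A methyl group, an ethyl chain or an amine there could give a very different number, and whether the same swap behaves alike on a different core is also unknown.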